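Fluoro for Methoxy on the Sulfonyl-Bearing Ring of Compound 1

The compounds below may be only part of what the source reports. "The series", "measured", "known", "first", "only" and "open" are said of these compounds alone.

Compound 1 (`COc1ccc(S(=O)(=O)c2nc3ccccc3nc2Nc2cc(OC)cc(OC)c2)cc1`) is the weakest of the three measured compounds in a functional assay on HL-60 cells (Homo sapiens) for cytotoxicity, read by MTT assay, with a stated time of 72 h (on this read-out higher numbers stand for weaker inhibition and lower numbers for stronger inhibition), where compound 1 gives 1710 nM. Both measured neighbours alter the ring on the nitrogen of the shared core. Compound 2 (`COc1ccc(S(=O)(=O)c2nc3ccccc3nc2Nc2cc(OC)c(OC)c(OC)c2)cc1`) gives 680 nM, a change of a 2.5-fold lower number from compound 1 to compound 2 (0.40 log units; beyond the scatter). Compound 3 (`COc1ccc(S(=O)(=O)c2nc3ccccc3nc2Nc2ccc(C(F)(F)F)cc2)cc1`) gives 220 nM, a change of a 7.8-fold lower number from compound 1 to compound 3 (0.89 log units; beyond the scatter). Both steps show modest gains from changes on that side of compound 1, yet neither touches the 4-methoxyphenyl ring.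

Compound 4 (`COc1cc(Nc2nc3ccccc3nc2S(=O)(=O)c2ccc(F)cc2)cc(OC)c1`) differs from compound 1 exactly there: fluoro in place of methoxy on an aromatic carbon. Going by the values given here, no measured step bears on this position, so there is no direct precedent for the size or direction of the change. With nothing shown to favour either direction, the step from compound 1 to compound 4 in this assay is expected to lie within the scatter, or at most be a small one. The implied step is expected to be a 1.3-fold lower number from compound 1 to compound 4 (0.12 log units; within the scatter). In this assay compound 4 is estimated at 1300 nM, with a range from 400 nM to 4500 nM.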

Compound 4, half-maximal inhibitory concentration: 2360 nM
For compound 4 the middle estimate is 1.8-fold (0.26 log units) below the measured one, and the stated range covers the measured number.
By their numbers in this assay, from the lowest: compound 3; then compound 2; then compounds 1 and 4 (each within the scatter of the next).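

In this assay, the exchange of 4-methoxyphenyl for 4-fluorophenyl gives a 1.4-fold higher number from compound 1 to compound 4 (0.14 log units; within the scatter), so this assay does not separate compound 4 from compound 1. Going by these compounds alone, this is the first reading on this ring, and it contrasts with the change on the nitrogen that gave a 7.8-fold lower number from compound 1 to compound 3 (0.89 log units; beyond the scatter): at this position, methoxy can give way to fluoro with no step beyond the scatter, at least with the 3,5-dimethoxyphenyl group in place. No measurement available here bears on what lies behind this result.

A single exchange at this position leaves open whether an amine, a carboxylic acid or a longer chain such as butoxy in the same place would also stay within the scatter of compound 1 or would move the number beyond it. From the compounds shown here alone, it is also open whether fluoro in place of methoxy would read the same in compound 2 or compound 3, whose groups on the nitrogen give lower numbers than that of compound 1.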